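Unsubstituted Pyrazole in Place of the Methylpyrazole

The source may report more compounds than this note shows. Statements on the series, on what has been measured and on what is new or still open speak of the compounds shown alone.

Compound 1 `c1ccc(-c2nc[nH]n2)c(NCC2=NCCN2)c1` gives 5.01 nM in an in vitro functional assay on cells (Fibroblast) for agonist activity at Alpha-1B adrenergic receptor (Homo sapiens); a lower number here means that less compound is needed, a higher number that more compound is needed for the effect.
Compound 2 `Cc1n[nH]c(-c2ccccc2NCC2=NCCN2)n1` gives only a limit in this assay, < 5020 nM.
Compound 3 `Cn1ccc(-c2ccccc2NCC2=NCCN2)n1` gives 50.1 nM in this assay.

Compound 3 holds the higher of the two real numbers: a 10-fold higher number from compound 1 to compound 3 (1.00 log units; beyond the scatter). Compound 2 sits at the assay limit (the limit of < 5020 nM in this assay, at which 1 of the 3 values shown sits), so a step that the limit leaves unreadable from compound 1 to compound 2 and a step that the limit leaves unreadable from compound 2 to compound 3 cannot be read. Compound 4 `c1ccc(-c2cn[nH]c2)c(NCC2=NCCN2)c1` differs from compound 3 by 1H-pyrazol-4-yl in place of 1-methyl-1H-pyrazol-3-yl on an aromatic carbon. Among the measured compounds shown here, the only readable step, a 10-fold higher number from compound 1 to compound 3 (1.00 log units; beyond the scatter), replaced an unmethylated azole with a methylated one and the number rose; compound 4 returns to an unmethylated azole, so a move back toward compound 1 is expected, a 2.5-fold lower number from compound 3 to compound 4 (0.40 log units; beyond the scatter). In this assay compound 4 is therefore estimated at 20 nM, between 5 nM and 100 nM.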

Compound 4, half-maximal effective concentration: 79.4 nM
The estimate for compound 4 lay 4.0-fold (0.60 log units) below the measured number; the range from low to high includes it.
By their numbers in this assay, from the lowest: compound 1; then compounds 3 and 4 (each within the scatter of the next).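

Putting 1H-pyrazol-4-yl in place of 1-methyl-1H-pyrazol-3-yl on the aromatic carbon gives a 1.6-fold higher number from compound 3 to compound 4 (0.20 log units; within the scatter) and so does not tell these two groups apart. Removing the methyl from the azole therefore does not by itself bring the number back toward compound 1, and the step to the unmethylated pyrazole remains a 16-fold higher number from compound 1 to compound 4 (1.20 log units; beyond the scatter) in this comparison. The steps involving compound 2 cannot be read: the limit of < 5020 nM in this assay, at which 1 of the 4 values shown sits.

Nothing measured here bears on why compound 1 stands apart.

From the compounds shown here alone, it remains open how an amine or a longer chain on the pyrazole would fare.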